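The compounds below may be only part of what the source reports. "The series", "measured", "known", "first", "only" and "open" are said of these compounds alone.

Compound 1 `COc1ccc2c(=O)c(/C=C/C(=O)NCc3ccccc3)coc2c1`: > 200000 nM
Compound 2 `Cc1ccccc1NC(=O)/C=C/c1coc2cc(O)ccc2c1=O`: > 200000 nM

Of the compounds shown here, two have been tested in a functional assay on L02 cells (Homo sapiens) for inhibition, read by MTT assay, with a stated time of 48 h; a higher number here means a weaker inhibitor, a lower number a stronger inhibitor. Compound 1 gives > 200000 nM, which is a limit of the assay rather than a measured number. Compound 2 gives > 200000 nM, again a limit and not a number. Compound 2 therefore stands at the edge of what the assay can report, as does everything measured here, see (the limit of > 200000 nM in this assay, at which 2 of the 2 values shown sit). Compound 3 `COc1ccc2c(=O)c(/C=C/C(=O)Nc3ccccc3C)coc2c1` differs from compound 2 by methyl in place of hydrogen on an oxygen on an aromatic ring. Among the compounds with values here, no step between measured compounds is available, so the size of this change cannot be read from a measured pair; the only guide is that both tested compounds, which differ from each other elsewhere in the structure, sit at the same limit. With nothing pointing to a gain in inhibition, the step from compound 2 to compound 3 is expected to be none beyond the scatter, a number no higher from compound 2 to compound 3 (the limit leaves the size open). Compound 3 is accordingly estimated at about 200000 nM, within 60000 nM to 600000 nM, most likely reported once more only as a limit.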

Compound 3, half-maximal inhibitory concentration: > 200000 nM
Compound 3 was reported as a limit; the forecaster's own chance of this, stated with the estimate: 85%; the middle value lies on the limit itself.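

Compound 3, like compound 1 and compound 2, reaches only a limit in this assay, so the steps from compound 2 to compound 3 and from compound 1 to compound 3 cannot be read: the limit of > 200000 nM in this assay, at which 3 of the 3 values shown sit.

The compounds shown leave open whether hydroxy to methoxy, or 2-methylphenyl in place of benzyl, changes inhibition at all.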